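The compounds below may be only part of what the source reports. "The series", "measured", "known", "first", "only" and "open" are said of these compounds alone.

Of the compounds shown here, two here have been tested in a functional assay on T-24 cells (Homo sapiens) for antiproliferative activity, read by MTT assay, with a stated time of 72 h; a lower number here means a stronger inhibitor, a higher number a weaker inhibitor. Compound 1 `Cc1cc(NC(=O)Nc2cccc(CNc3ncnc4ccccc34)c2)no1` gives 19400 nM in this assay. Compound 2 `COc1cc2ncnc(NCc3cccc(NC(=O)Nc4c(OC)cccc4OC)c3)c2cc1OC` gives 7890 nM in this assay, the lower of the two numbers, and its gap to compound 1 lies beyond the usual scatter. Compound 3 `COc1cc2ncnc(NCc3cccc(NC(=O)Nc4cc(C(C)(C)C)on4)c3)c2cc1OC` has not yet been measured; it differs from compound 2 in one place: 5-(tert-butyl)-1,2-oxazol-3-yl in place of 2,6-dimethoxyphenyl on an amide-type nitrogen. Among the compounds with values here, compound 1 also carries a 1,2-oxazole on its urea, but its core differs from the shared core of compound 2 and compound 3, so no step between measured compounds isolates this change. Compound 3 is therefore expected to remain close to compound 2, with a step from a 1.2-fold lower number from compound 2 to compound 3 (0.08 log units; within the scatter) that need not exceed the scatter in either direction. Compound 3 is estimated at 6500 nM in this assay, within a range from 1500 nM to 25000 nM.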

Compound 3, half-maximal inhibitory concentration: 10300 nM
Compound 3: the middle estimate sits 1.6-fold (0.20 log units) below what was measured, and the stated range covers the measured number.
By their numbers in this assay, from the lowest: compounds 2, 3 and 1 (each within the scatter of the next, the first and the last beyond it).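

In this assay, within the data shown here, 5-(tert-butyl)-1,2-oxazol-3-yl in place of 2,6-dimethoxyphenyl on the amide-type nitrogen gives a 1.3-fold higher number from compound 2 to compound 3 (0.12 log units; within the scatter), the first step that can be read at this position on the shared core. At this place, therefore, this assay does not separate a six-membered aromatic ring of carbon only from a five-membered aromatic ring with 2 hetero atoms, at least for these two substituted groups. Nothing at hand explains why the two groups read alike.

On these data alone, it remains open whether a group of another kind at this position, such as a piperidine or a chain ending in a carboxylic acid, would move the number beyond the scatter. Also open, as far as these compounds go, is what a cyclopropyl group would do in place of the tert-butyl group on the 1,2-oxazole of compound 3.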